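A pyridinyl swap and its expected cytotoxicity

A few compounds are considered here, and "the series" means these few. Any claim that something is new, unique, unknown or untested is made for them only; others in the source may bear on it.

compound 1 `COc1ccc(CN2CCN(c3ccc(C4CC(c5ccc([N+](=O)[O-])o5)=NO4)cc3)CC2)cn1` — in an ADME assay on HeLa cells (Homo sapiens) for cytotoxicity, read by MTT assay, with a stated time of 96 h (on this read-out higher numbers stand for weaker inhibition and lower numbers for stronger inhibition), compound 1 gives > 50000 nM
compound 2 `O=[N+]([O-])c1ccc(C2=NOC(c3ccc(-c4cccnc4)cc3)C2)o1` — in this assay compound 2 gives > 50000 nM
compound 3 `O=[N+]([O-])c1ccc(C2=NOC(c3ccc(N4CCN(Cc5cccnc5)CC4)cc3)C2)o1` — in this assay compound 3 gives > 50000 nM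

Each of these three values is a limit of the assay, not a number. Compound 2 therefore cannot be ordered against compound 1 or compound 3: all that is known is the limit of > 50000 nM in this assay, at which 3 of the 3 values shown sit.

Compound 4 `O=[N+]([O-])c1ccc(C2=NOC(c3ccc(-c4ccccn4)cc3)C2)o1` is obtained from compound 2 by pyridin-2-yl in place of pyridin-3-yl on an aromatic carbon. For the measured compounds named here, the only measured step, a step that the two limits leave unreadable from compound 1 to compound 3, concerns a different change and its size is not readable, so no measured step bears on this one. The expected step is a step that the limit leaves unreadable from compound 2 to compound 4, which means no readable change, with a limit the most likely outcome. Compound 4 is estimated at 60000 nM, with a range from 20000 nM to 200000 nM.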

Compound 4, half-maximal inhibitory concentration: > 50000 nM
Compound 4 gave a limit, no number (the forecaster's own chance of this, stated with the estimate: 85%); the middle value lies beyond the limit too.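

Compound 2 and compound 4 both give a limit rather than a number in this assay, and no step can be read between them. The compounds shown leave open whether pyridin-2-yl and pyridin-3-yl differ at all here.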